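Methoxy for Methyl on the Anilino Ring

The compounds below may be only part of what the source reports. "The series", "measured", "known", "first", "only" and "open" are said of these compounds alone.

Compound 3 `CCOC(=O)c1c(-c2ccc(Cl)cc2)cc(-c2ccccc2)nc1Nc1ccc(C)cc1` stands second highest of the three measured compounds in a functional assay on the whole organism (strain Wister albino) for inhibition, with Rattus norvegicus as the target, read by paw edema, with stated times of 1 h and 4 h, at a dose of 50 mg/kg by the intraperitoneal route (on this read-out lower numbers stand for less inhibition and higher numbers for more inhibition at the one dose given (going by the name of the read-out)), where compound 3 gives 90.9%. Compound 2 `CCOC(=O)c1c(-c2ccc(Cl)cc2)cc(-c2ccccc2)nc1Nc1ccccc1` gives 123%, and compound 1 `CCOC(=O)c1c(-c2ccc(Cl)cc2)cc(-c2ccccc2)nc1N1CCN(C)CC1` gives 55.6%. Compound 4 `CCOC(=O)c1c(-c2ccc(Cl)cc2)cc(-c2ccccc2)nc1Nc1ccc(OC)cc1` differs from compound 3 by methoxy in place of methyl on an aromatic carbon. Among the measured compounds shown here, only one measured step touches the same ring: a number 32.1 percentage points lower from compound 2 to compound 3 (beyond the scatter). For the measured compounds named here, no measured step shows how methoxy compares with methyl at that place; the steps of a number 67.4 percentage points higher from compound 1 to compound 2 (beyond the scatter) and a number 35.3 percentage points higher from compound 1 to compound 3 (beyond the scatter) concern a different change. For compound 4 the expected step is therefore a number 5.9 percentage points lower from compound 3 to compound 4 (within the scatter), a modest move in either direction or none beyond the scatter. Compound 4 is expected to give 85%, between 60% and 115%.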

Compound 4, a percentage reported as inhibition, in the whole organism at one dose (the size of the read-out at that dose, not a potency): 57.2%
Compound 4: middle estimate off by 27.8 percentage points, on the high side; the measured number lies below the stated range.
By their numbers in this assay, from the lowest: compounds 1 and 4 (each within the scatter of the next); then compound 3; then compound 2.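

At this place on the ring, the kind of group matters and not just its presence: in this assay, methoxy in place of methyl gives a number 33.7 percentage points lower from compound 3 to compound 4 (beyond the scatter) for a change of only one added oxygen. With a number 65.8 percentage points lower from compound 2 to compound 4 (beyond the scatter), methoxy lowers the number further than methyl does, starting from the same unsubstituted ring. The (4-methoxyphenyl)amino group also no longer stands apart from 4-methylpiperazin-1-yl, with a number 1.6 percentage points higher from compound 1 to compound 4 (within the scatter) as the step.

Nothing available explains these drops. Going by these compounds, whether a fluorine atom, an amine or a carboxylic acid at this place would come closer to the unsubstituted ring remains open.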